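Compound 3 and Its Mirror Image

The source may hold more compounds than are shown below. What is called first, only, known or untested is meant among the compounds shown, and "the series" means these compounds.

Of the compounds shown here, three have been measured in a toxicity assay on MT4 cells (Homo sapiens) for cytotoxicity, read by MTT assay; a higher number here means that more compound is tolerated, a lower number that less compound is tolerated. Compound 1 `O=c1ccn([C@@H]2C=C[C@@]3(CO)C[C@@H]23)c(=O)[nH]1` gives > 100 ug/mL, which is a limit of the assay and not a number. Compound 2 `Cc1cn([C@H]2C=C[C@]3(CO)C[C@H]23)c(=O)[nH]c1=O` gives a true reading of 8.56 ug/mL. Compound 3 `Nc1ncnc2c1ncn2[C@@H]1C=C[C@@]2(CO)C[C@@H]12` gives > 100 ug/mL, again only a limit. Most of the set therefore stands at one mark, namely (the limit of > 100 ug/mL in this assay, at which 2 of the 3 values shown sit), and compound 3 has no exact number of its own.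

Compound 4 `Nc1ncnc2c1ncn2[C@H]1C=C[C@]2(CO)C[C@H]12` is the next to be measured. Its relation to compound 3 is simple to state: the two compounds have the same atoms and bonds and differ only in configuration as drawn: 3 of 3 stereo elements differ (all stereocentres are inverted: mirror images); a stereocentre at a saturated ring carbon is drawn R in compound 3 and S in compound 4; a stereocentre at a saturated ring carbon is drawn S in compound 3 and R in compound 4; a stereocentre at a saturated ring carbon is drawn R in compound 3 and S in compound 4. The two compounds have the same atoms and bonds, and all stereocentres are inverted, which makes them mirror images.

Among the compounds with values here, no measured pair in the set isolates such a change, so its size cannot be read directly from the data. The expected direction in this assay is towards less compound being tolerated, if there is any shift at all. The estimated step is an at least 2.0-fold lower number from compound 3 to compound 4 (0.30 log units; that floor lies within the scatter). Compound 2, at 8.56 ug/mL, shows that an exact reading does occur in this set, so the expected range stays wide. For compound 4 the estimate is 50 ug/mL, with an expected range of 8 ug/mL to 150 ug/mL.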

Compound 4, half-maximal cytotoxic concentration: > 100 ug/mL
Compound 4: no number, only a limit; the forecaster's own chance of this, stated with the estimate: 50%; middle value at least 2.0-fold (0.30 log units) from the limit.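

In this assay compound 4 gives > 100 ug/mL, which is a limit of the assay and not a number. Within the data shown here, compound 3 also stands at a limit, so no step between compound 3 and compound 4 can be read. The compounds shown leave open whether these two mirror images differ at all in this assay.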